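Longer Chains on a Shared Core in the Rat

The compounds below may be only part of what the source reports. "The series", "measured", "known", "first", "only" and "open" are said of these compounds alone.

Compound 1 `CCCCc1ccc(-c2c(C)[nH]c(=O)n2C)cc1` and compound 2 `CCCCCCc1ccc(-c2c(C)[nH]c(=O)n2C)cc1` share a core and differ by ethyl in place of hydrogen on a saturated chain carbon, four bonds along the chain from an aromatic carbon. In a functional assay on the whole organism with Rattus norvegicus as the target (on this read-out lower numbers stand for an effect already at smaller amounts and higher numbers for an effect only at larger amounts of compound), compound 1 gives 0.1 mg/kg, and compound 2 gives 0.3 mg/kg, a step of a 3.0-fold higher number from compound 1 to compound 2 (0.48 log units; beyond the scatter). Compound 3 `CCCCCCCCOc1ccc(-c2c(C)[nH]c(=O)n2C)cc1` carries a different chain; how its core differs from that of compound 1 is not broken down here. In this assay compound 3 gives 30 mg/kg, the highest of the three numbers. Compound 4 `CCCCCCCCCCOc1ccc(-c2c(C)[nH]c(=O)n2C)cc1` differs from compound 3 by ethyl in place of hydrogen on a saturated chain carbon, eight bonds along the chain from an oxygen on an aromatic ring, the same kind of change as between compound 1 and compound 2, but placed eight bonds along the chain from an oxygen on an aromatic ring rather than four bonds from an aromatic carbon. For the measured compounds named here, the earlier step, a 3.0-fold higher number from compound 1 to compound 2 (0.48 log units; beyond the scatter), is the only guide. For compound 4 in this assay a step of a 3.3-fold higher number from compound 3 to compound 4 (0.52 log units; beyond the scatter) is expected. Compound 4 is therefore estimated at 100 mg/kg, most likely between 30 mg/kg and 300 mg/kg.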

Compound 4, minimum effective dose: 0.1 mg/kg
Estimate against measurement, compound 4: 1000-fold (3.00 log units) above; the measured number lies below the stated range.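

In this assay, ethyl in place of hydrogen on a saturated chain carbon, eight bonds along the chain from an oxygen on an aromatic ring, gives a 300-fold lower number from compound 3 to compound 4 (2.48 log units; beyond the scatter). Set beside the earlier step, the same change does not carry over from one core to the other, in size or in direction: the same change on two cores in this assay, a 3.0-fold higher number (0.48 log units; beyond the scatter) from compound 1 to compound 2 and a 300-fold lower number (2.48 log units; beyond the scatter) from compound 3 to compound 4, 900-fold (2.95 log units) apart, beyond the scatter of two such steps. These two pairs show that the outcome of this change depends on its setting, but they do not tell whether the chain length or the oxygen on the aromatic ring decides it, and they give no rule for other cores.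

The compounds shown leave open what a longer chain would do on either core. They also leave open how a chain carrying an amine or a carboxylic acid would behave.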